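Replacing an arylamino group with dipropylamino on the shared core

The compounds below may be only part of what the source reports. "The series", "measured", "known", "first", "only" and "open" are said of these compounds alone.

This account follows one change within a small set built on a common fused core. Compound 1 `Cc1ccc(NC2=CC(=O)c3nc4n(c3C2=O)[C@H]2OC[C@@H](O)[C@H]2OC4)cc1` and compound 2 `COc1ccccc1NC1=CC(=O)c2c(nc3n2[C@H]2OC[C@@H](O)[C@H]2OC3)C1=O` both carry an arylamino group on a double-bonded ring carbon; in a functional assay on HeLa cells (Homo sapiens) for inhibition, read by sulforhodamine B assay (on this read-out lower numbers stand for stronger inhibition and higher numbers for weaker inhibition), compound 1 gives 3860 nM and compound 2 gives 7460 nM, and these two numbers sit within the scatter of one another. Compound 3 `O=C1C(N2CCCC2)=CC(=O)c2c1nc1n2[C@H]2OC[C@@H](O)[C@H]2OC1` carries a pyrrolidin-1-yl group at the same place, and in this assay compound 3 reaches only the limit > 16000 nM, which is a boundary of the assay rather than a number. For the measured compounds named here, the one step measured across such a change, an at least 2.1-fold higher number from compound 2 to compound 3 (0.33 log units; beyond the scatter), points to weaker inhibition when an arylamino group gives way to a dialkylamino group, with the size of the step bounded by the limit of > 16000 nM in this assay, at which 1 of the 3 values shown sits.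

Compound 4 `CCCN(CCC)C1=CC(=O)c2nc3n(c2C1=O)[C@H]1OC[C@@H](O)[C@H]1OC3` differs from compound 1 in the same manner: dipropylamino in place of (4-methylphenyl)amino on a double-bonded ring carbon. By analogy to that step, compound 4 is expected to show weaker inhibition, a step of a 3.9-fold higher number from compound 1 to compound 4 (0.59 log units; beyond the scatter). For compound 4 the estimate in this assay is 15000 nM, expected to lie between 6000 nM and 40000 nM, with a fair chance that only a limit is reported.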

Compound 4, half-maximal inhibitory concentration: > 16000 nM
Compound 4 gave a limit, no number; the forecaster's own chance of this, stated with the estimate: 50%; at least 1.0-fold (0.02 log units) between middle value and limit.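

With an at least 4.1-fold higher number from compound 1 to compound 4 (0.61 log units; beyond the scatter), the weaker inhibition seen on leaving an arylamino group on this double-bonded ring carbon now appears in a second pair of compounds, and it is no longer tied to the pyrrolidin-1-yl ring of compound 3, since the open-chain dipropylamino group of compound 4 also ends at a limit. This change removes both the six-membered aromatic ring and the hydrogen-bond donor of the (4-methylphenyl)amino group, and the data cannot separate the two. The true size of the step remains unknown, as the dialkylamino compounds give no number: the limit of > 16000 nM in this assay, at which 2 of the 4 values shown sit.

Still open, from the compounds shown here alone, is whether a propylamino group, which keeps the hydrogen on nitrogen without the aromatic ring, would retain inhibition. The same question stands for a methyl(phenyl)amino group, which keeps the ring without that hydrogen.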